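Leaving the limit: from dihydroxyphenyl to trifluoromethylphenyl

The compounds below may be only part of what the source reports. "The series", "measured", "known", "first", "only" and "open" are said of these compounds alone.

Values in a functional assay on K562 cells (Homo sapiens) for antiproliferative activity, with a stated time of 72 h; a higher number here means a weaker inhibitor, a lower number a stronger inhibitor:
- Compound 1 `OC[C@H]1O[C@@H](n2cnc3c(NCc4ccc(F)cc4F)ncnc32)[C@H](O)[C@@H]1O`: 9600 nM
- Compound 2 `OC[C@H]1O[C@@H](n2cnc3c(NCc4ccc(F)c(F)c4F)ncnc32)[C@H](O)[C@@H]1O`: > 166000 nM (a limit)
- Compound 3 `OC[C@H]1O[C@@H](n2cnc3c(NCc4cc(O)cc(O)c4)ncnc32)[C@H](O)[C@@H]1O`: > 166000 nM (a limit)

Compound 3 has no exact number, only a limit. Compound 3 stands at the limit of > 166000 nM in this assay, at which 2 of the 3 values shown sit.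

Compound 4 `OC[C@H]1O[C@@H](n2cnc3c(NCc4cccc(C(F)(F)F)c4)ncnc32)[C@H](O)[C@@H]1O` keeps the shared core and changes only the ring group on a saturated chain carbon bound to a nitrogen on an aromatic ring: 3-(trifluoromethyl)phenyl in place of 3,5-dihydroxyphenyl on a saturated chain carbon bound to a nitrogen on an aromatic ring. Thus 3-(trifluoromethyl)phenyl takes the place of 3,5-dihydroxyphenyl.

The nearest measured evidence is an at least 17-fold higher number from compound 1 to compound 3 (1.23 log units; beyond the scatter), a large step in which 3,5-dihydroxyphenyl replaced 2,4-difluorophenyl. Read in reverse, it suggests that removing 3,5-dihydroxyphenyl could restore a measurable value, as compound 1 shows with 9600 nM. Compound 2 goes against any simple rule that fluorine-bearing rings keep activity, given an at least 17-fold higher number from compound 1 to compound 2 (1.23 log units; beyond the scatter), which is also large. A step toward a lower number in this assay is therefore expected, though a smaller gain than full recovery to compound 1 is likely, and another limit remains possible.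

The estimated step is an at least 4.1-fold lower number from compound 3 to compound 4 (0.61 log units; beyond the scatter). For compound 4 the estimated value is 40000 nM, with an expected range of 7000 nM to 166000 nM.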

Compound 4, half-maximal inhibitory concentration: > 166000 nM
Compound 4: no number, only a limit; the forecaster's own chance of this, stated with the estimate: 45%; at least 4.1-fold (0.61 log units) between middle value and limit.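

In this assay, compound 4 shows that fluorine held in a trifluoromethyl group, on a ring with no hydroxyl groups, also gives only a limit, so leaving the 3,5-dihydroxyphenyl ring does not by itself restore a measurable value. Set against compound 1, the only compound shown with an exact number, the change to 3-(trifluoromethyl)phenyl is an at least 17-fold higher number from compound 1 to compound 4 (1.23 log units; beyond the scatter). The steps among compound 2, compound 3 and compound 4 cannot be read, since all three carry only a limit, and three differently substituted rings on the saturated chain carbon now end at the same place, with compound 1 the one exception: the limit of > 166000 nM in this assay, at which 3 of the 4 values shown sit.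

On these data alone, what remains open is what sets the 2,4-difluorophenyl ring of compound 1 apart, for example whether a plain phenyl ring, or a ring carrying a single fluorine, a methoxy group or an amine, would give an exact number. The three limits also cannot be ranked against one another, so any real differences among compound 2, compound 3 and compound 4 stay hidden.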